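This account rests on a few compounds, and the source may have more. Where it says the series, first, only, none or still open, it means among the compounds named here.

In an assay on isolated protein (urine) for inhibition of Myeloperoxidase (Homo sapiens), with a stated time of 5 min (a higher number here means a weaker inhibitor, a lower number a stronger inhibitor), compound 1 `NCCSCCc1c[nH]c2ccc(F)cc12` gives 4 nM and compound 2 `N#CSCCCc1c[nH]c2ccc(F)cc12` gives 5 nM. Compound 3 `NC(=O)CCc1c[nH]c2ccc(F)cc12` gives 132 nM, the highest of the three numbers; the steps of a 33-fold higher number from compound 1 to compound 3 (1.52 log units; beyond the scatter) and a 26-fold higher number from compound 2 to compound 3 (1.42 log units; beyond the scatter) are both large, whereas a 1.3-fold higher number from compound 1 to compound 2 (0.10 log units; within the scatter). Compound 4 `CCNC(=O)CCCc1c[nH]c2ccc(F)cc12` differs from compound 3 by (ethylcarbamoyl)methyl in place of carbamoyl on a saturated chain carbon, two bonds along the chain from an aromatic carbon. For the measured compounds named here, no measured step matches this change: each step that reaches compound 3 replaces a (2-aminoethyl)sulfanyl or (cyanosulfanyl)methyl group with carbamoyl, and none exchanges one amide for a longer, ethyl-bearing amide. The expectation for compound 4 is therefore only a modest change in this assay, with the direction left open, a 1.1-fold higher number from compound 3 to compound 4 (0.06 log units; within the scatter). Compound 4 is estimated at 150 nM, with a likely range from 40 nM to 600 nM.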

Compound 4, half-maximal inhibitory concentration: 182 nM
Compound 4: the middle estimate sits 1.2-fold (0.08 log units) below what was measured; low and high end bracket the measured number.
By their numbers in this assay, from the lowest: compounds 1 and 2 (each within the scatter of the next); then compounds 3 and 4 (each within the scatter of the next).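

In this assay, putting (ethylcarbamoyl)methyl in place of carbamoyl adds heavy atoms on the saturated chain, yet the step is a 1.4-fold higher number from compound 3 to compound 4 (0.14 log units; within the scatter), so the larger amide and the smaller one cannot be told apart here. The larger amide also stays far from the two non-amide compounds, with a 36-fold higher number from compound 2 to compound 4 (1.56 log units; beyond the scatter) and a 46-fold higher number from compound 1 to compound 4 (1.66 log units; beyond the scatter), so extending the amide does not close that gap. Nothing measured here explains the size of these steps.

On these data alone, whether a carboxylic acid or a sulfonamide at this place on the chain would behave like the amides or like compound 1 remains open.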